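Fluorine on the benzyl ring in two related ureas

The source may report more compounds than this note shows. Statements on the series, on what has been measured and on what is new or still open speak of the compounds shown alone.

Compound 1 `COc1ccc(N(Cc2ccccc2)NC(=O)NCCCN2CCN(c3ccccc3OC)CC2)cc1`: 1.7 nM
Compound 2 `COc1ccc(N(Cc2ccccc2F)NC(=O)NCCCN2CCN(c3ccccc3OC)CC2)cc1`: 2.6 nM
Compound 3 `O=C(NCCCN1CCN(c2ccc(Cl)cc2)CC1)NN(Cc1ccccc1)c1ccccc1`: 9.7 nM

Of the compounds shown here, three have been measured in an assay on CHO cells for displacement of a labelled ligand from D(4) dopamine receptor (Homo sapiens), read by radioligand binding; on this read-out higher numbers stand for weaker inhibition and lower numbers for stronger inhibition. Compound 1 gives 1.7 nM and compound 2, which carries fluoro in place of hydrogen on an aromatic carbon, gives 2.6 nM; the step between them is a 1.5-fold higher number from compound 1 to compound 2 (0.18 log units; within the scatter). The core of compound 3 differs from that of compound 1 in a way that is not broken down here. Compound 3 gives 9.7 nM, the highest of the three numbers and beyond the scatter from both others.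

Compound 4 `O=C(NCCCN1CCN(c2ccc(Cl)cc2)CC1)NN(Cc1ccc(F)cc1)c1ccccc1` has not yet been measured. It carries fluoro in place of hydrogen on an aromatic carbon relative to compound 3. This is the same kind of change as that from compound 1 to compound 2, but not the same: there the fluoro sits ortho to a large group, here it sits para to a large group. Going by the values given here, because the only measured instance of this kind of change gave a 1.5-fold higher number from compound 1 to compound 2 (0.18 log units; within the scatter), the step from compound 3 to compound 4 is expected to be small as well, estimated at a 1.2-fold higher number from compound 3 to compound 4 (0.09 log units; within the scatter). Compound 4 is therefore expected to give about 12 nM, most likely between 5 nM and 28 nM.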

Compound 4, inhibition constant: 17 nM
Estimate against measurement, compound 4: 1.4-fold (0.15 log units) below; low and high end bracket the measured number.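

In this assay, fluoro in place of hydrogen on an aromatic carbon leaves the core of compound 3 with a small step, a 1.8-fold higher number from compound 3 to compound 4 (0.24 log units; within the scatter). Set beside the earlier step on the core of compound 1, the change reads much the same on both cores: the same change on two cores in this assay, a 1.5-fold higher number (0.18 log units; within the scatter) from compound 1 to compound 2 and a 1.8-fold higher number (0.24 log units; within the scatter) from compound 3 to compound 4, 1.1-fold (0.06 log units) apart, within the scatter of two such steps. This shows that, in these two instances, the change carried from one core to the other without a step beyond the scatter, but it does not show that fluoro has a real effect on either core, nor that the result would hold on further cores or at other places on the ring, as the two instances differ in both core and fluoro position.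

The compounds shown leave open whether a larger group on the benzyl ring, such as bromo or trifluoromethyl, would give a step as small as these. They also leave open how a longer chain at the urea would read, and which of the differences between the cores of compound 1 and compound 3 matter.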